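An Ester Replaces a Urea on the Shared Core

The compounds below may be only part of what the source reports. "The series", "measured", "known", "first", "only" and "open" are said of these compounds alone.

Compounds 2 and 3 share one core, seen in compound 2 `CCNC(=O)Nc1cc(=O)oc2cc(OCc3cccc(Cl)c3)ccc12`. Going by the values given here, in an assay on isolated protein (strain Sprague-Dawley) for inhibition of Amine oxidase [flavin-containing] A (Rattus norvegicus), read by spectrophotometry, with a stated time of 5 min, tested at 10 uM (a higher number here means more inhibition at the concentration tested (going by the name of the read-out), a lower number less inhibition), compound 2 gives 0%, the lowest of the two numbers measured so far; its nearest neighbour is compound 1 `CN(C)C(=O)COc1cc(=O)oc2cc(OCc3cccc(Cl)c3)ccc12`, which in this assay gives 10%. Among the compounds with values here, the only measured step, a number 10 percentage points lower from compound 1 to compound 2 (within the scatter), stays within the scatter.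

Compound 3 `CCOC(=O)c1cc(=O)oc2cc(OCc3cccc(Cl)c3)ccc12` differs from compound 2 in one place: ethoxycarbonyl in place of (ethylcarbamoyl)amino on an aromatic carbon. Within the data shown here, no measured step exchanges these two groups directly. Among the measured compounds shown here, the single step available, also a change of group on an aromatic carbon of the core, moved the number by a number 10 percentage points lower from compound 1 to compound 2 (within the scatter) and did not leave the scatter. With both measured compounds low in this assay, a change of this kind is expected to give no step beyond the scatter, so the expected step is a number 5 percentage points higher from compound 2 to compound 3 (within the scatter). Compound 3 is therefore estimated at 5%, with a range from 0% to 20%.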

Compound 3, a percentage reported as inhibition, at one concentration (the size of the read-out at that concentration, not a potency): 4.4%
The estimate for compound 3 lay 0.6 percentage points above the measured number; the range from low to high includes it.
By their numbers in this assay, from the lowest: compounds 2, 3 and 1 (each within the scatter of the next).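

In this assay, ethoxycarbonyl in place of (ethylcarbamoyl)amino gives a number 4.4 percentage points higher from compound 2 to compound 3 (within the scatter) and so replaces a group with hydrogen-bond donors by one without them, with no change beyond the scatter. Ethoxycarbonyl in place of (dimethylcarbamoyl)methoxy gives a number 5.6 percentage points lower from compound 1 to compound 3 (within the scatter) and also stays within the scatter, so all three groups on this aromatic carbon of the shared core now read alike, and all low, at the single concentration tested. Nothing available here explains why these three groups read alike.

As far as these compounds go, it remains open whether any group at this position can lift the number clear of the scatter, for example a carboxylic acid or a simple amine in place of ethoxycarbonyl. A reading at one concentration also leaves open how these compounds would behave at higher concentrations.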